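Fluoro for methoxy at the cinnamoyl end: compound 3

This account rests on a few compounds, and the source may have more. Where it says the series, first, only, none or still open, it means among the compounds named here.

Measured in a functional assay on DU-145 cells (Homo sapiens) for cytotoxicity, read by MTT assay, with a stated time of 72 h; a lower number here means a stronger inhibitor, a higher number a weaker inhibitor:
compound 1 `COc1ccc(/C=C/C(=O)Nc2cc(C(=O)c3cc(OC)c(OC)c(OC)c3)ccc2OC)cc1`: 12800 nM
compound 2 `COc1ccc(/C=C/C(=O)Nc2cc(C(=O)c3cc(OC)c(OC)c(OC)c3)cc(OC)c2OC)cc1`: 10400 nM

For the measured compounds named here, compound 2 carries the lowest of the two numbers so far; its nearest neighbour is compound 1, and the only measured step, a 1.2-fold lower number from compound 1 to compound 2 (0.09 log units; within the scatter), stays within the scatter, so the two cannot be ordered against each other.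

Compound 3 `COc1cc(C(=O)c2cc(OC)c(OC)c(OC)c2)cc(NC(=O)/C=C/c2ccc(F)cc2)c1OC` is not yet measured. Relative to compound 2 it shows (fluoro in place of methoxy on an aromatic carbon). Going by the values given here, this is a change at a different place from the one probed by the step from compound 1 to compound 2, which added a methoxy on the core; no measured pair varies the group on the outer ring at all. Among the compounds with values here, the one step that exists is therefore not a guide to this change, and on the data at hand nothing points to a shift in either direction in this assay.

The working expectation for compound 3 is a number near that of compound 2, an estimated step of a 1.0-fold lower number from compound 2 to compound 3 (0.02 log units; within the scatter), so that compound 3 is estimated at 10000 nM with a range from 3500 nM to 28000 nM.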

Compound 3, half-maximal inhibitory concentration: 6700 nM
Compound 3: the middle estimate sits 1.5-fold (0.17 log units) above what was measured; low and high end bracket the measured number.
By their numbers in this assay, from the lowest: compounds 3, 2 and 1 (each within the scatter of the next).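

The outer ring at the cinnamoyl end, left unchanged by the earlier pair, now has its first measured variation: in this assay the change from 4-methoxyphenyl to 4-fluorophenyl gives a 1.6-fold lower number from compound 2 to compound 3 (0.19 log units; within the scatter) and leaves the two compounds unordered. For the compounds shown here, on this aromatic carbon, para to a large group, a methoxy of 2 heavy atoms and 1 hydrogen-bond acceptor can therefore give way to a fluoro of 1 heavy atom and no hydrogen-bond acceptor with no step that stands clear of repeated measurement. No supporting measurement is at hand that could tie this result to a property of either group.

On these data alone, whether another group on this carbon, such as an amine, a carboxylic acid or a nitrile, would give a step beyond the scatter remains open. Also open, as far as these compounds go, is whether the same fluoro-for-methoxy change would read alike on the core of compound 1, which lacks the added core methoxy of compound 2.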